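A few compounds are considered here, and "the series" means these few. Any claim that something is new, unique, unknown or untested is made for them only; others in the source may bear on it.

In a physicochemical assay for solubility, measured as kinetic solubility (a lower number here means a less soluble compound, a higher number a more soluble compound), compound 3 `CCC/N=C1\S/C(=C\c2ccc(O)c(Br)c2)C(=O)N1c1ccccc1C` gives 79000 nM, the lowest number among those shown. Compound 2 `CCC/N=C1\S/C(=C\c2ccc(O)c(Cl)c2)C(=O)N1c1ccccc1O` gives 220000 nM, higher by more than the scatter. Compound 1 `CCC/N=C1\S/C(=C\c2ccc(O)c(Cl)c2)C(=O)N1C1CCN(C)C(=O)C1` returns only a limit in this assay, > 250000 nM. Compound 4 `CCC/N=C1\S/C(=C\c2ccc(O)c(Cl)c2)C(=O)N1c1ccccc1C` differs from compound 3 in one place: chloro in place of bromo on an aromatic carbon, on an aromatic carbon, ortho to a hydroxy group. Among the measured compounds shown here, the only measured step, an at least 1.1-fold lower number from compound 1 to compound 2 (0.05 log units; that floor lies within the scatter), changes the group on the amide-type nitrogen rather than the bromo or chloro group, so it bears only loosely on this change. For the measured compounds named here, no measured pair isolates the swap, and only a modest rise in this assay is expected, a 1.5-fold higher number from compound 3 to compound 4 (0.18 log units; within the scatter). Compound 4 is estimated at 120000 nM, with an expected range of 60000 nM to 240000 nM.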

Compound 4, solubility: 79000 nM
Beside the measured number, compound 4's estimate is 1.5-fold (0.18 log units) above it; the measured number falls inside the stated range.
By their numbers in this assay, from the lowest: compounds 3 and 4 (each within the scatter of the next); then compound 2. At a limit, above all of these: compound 1.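

In this assay, the swap on the aromatic carbon ortho to a hydroxy group gives no change at the digits printed from compound 3 to compound 4 (within the scatter), so in this one pair bromo and chloro read alike. With chloro held, the group changes elsewhere give a 2.8-fold lower number from compound 2 to compound 4 (0.44 log units; beyond the scatter) and an at least 3.1-fold lower number from compound 1 to compound 4 (0.50 log units; beyond the scatter). The second of these steps is only a floor, as compound 1 stands at a limit: the limit of > 250000 nM in this assay, at which 1 of the 4 values shown sits.

From the compounds shown here alone, whether the swap reads the same with 2-hydroxyphenyl or 1-methyl-2-oxopiperidin-4-yl on the amide-type nitrogen stays open. So does what fluoro or methoxy would give at this position.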